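A few compounds are considered here, and "the series" means these few. Any claim that something is new, unique, unknown or untested is made for them only; others in the source may bear on it.

Measured compounds:
Compound 1 `OC[C@H](NC[C@H]1NC[C@H](O)[C@@H]1O)c1ccc(-c2ccccc2)cc1`: > 200000 nM
Compound 2 `OC[C@H](NC[C@H]1NC[C@H](O)[C@@H]1O)c1ccc(-c2ccsc2)cc1`: "not active" (no number reported)
Compound 3 `C=CCOc1ccc([C@H](CO)NC[C@H]2NC[C@H](O)[C@@H]2O)cc1`: > 200000 nM

All three measured compounds share the core of compound 1. In a functional assay on MCF7 cells (Homo sapiens) for cytotoxicity, read by colorimetric assay, with a stated time of 72 h (on this read-out lower numbers stand for stronger inhibition and higher numbers for weaker inhibition), compound 1 gives > 200000 nM, which is a limit of the assay and not a number. Compound 2 is reported in this assay as "not active" (no number reported), without a number. For compound 3, this assay gives > 200000 nM, again a limit and not a number. Compound 3 thus stands at the limit of > 200000 nM in this assay, at which 2 of the 3 values shown sit, and nothing in the series shows a measured number. The step that the two limits leave unreadable from compound 1 to compound 3 runs between two limits and its size is not readable.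

Compound 4 `OC[C@H](NC[C@H]1NC[C@H](O)[C@@H]1O)c1ccc(OCc2ccccc2)cc1` has not been measured. It differs from compound 3 by phenyl in place of vinyl on a saturated chain carbon bound to an oxygen on an aromatic ring. For the measured compounds named here, the only measured step that touches this aromatic position, a step that the two limits leave unreadable from compound 1 to compound 3, gives no size, so no direction can be read from the data. Both compound 1 and compound 3 sit at the limit. The expected step of a number no higher from compound 3 to compound 4 (the limit leaves the size open) is therefore none beyond the scatter, with a limit again the most likely report. Compound 4 is expected at 200000 nM, in the range 80000 nM to 600000 nM.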

Compound 4, half-maximal inhibitory concentration: "not active" (no number reported)
Compound 4 has no reported number here; no gap can be computed for the estimate.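

No new step can be read from compound 3 to compound 4: compound 4 carries no number in this assay and compound 3 stands only at a limit. The compounds shown leave open whether any change on the shared core yields a measurable cytotoxic value.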